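A Hydroxyl Swap at the Limit of Detection

This account rests on a few compounds, and the source may have more. Where it says the series, first, only, none or still open, it means among the compounds named here.

In an ADME assay on HepG2 cells (Homo sapiens) for cytotoxicity, read by MTT assay (on this read-out lower numbers stand for stronger inhibition and higher numbers for weaker inhibition), compound 2 `O=C(N/N=C/c1ccc(Cl)cc1)c1ccc(C(F)(F)F)cc1` gives > 100000 nM, which is a limit of the assay and not a number. Compound 1 `O=C(N/N=C/c1cc(Cl)ccc1O)c1ccc(C(F)(F)F)cc1`, which also carries a hydroxyl on its ring, gives > 100000 nM, again a limit. All that is known so far is the limit of > 100000 nM in this assay, at which 2 of the 2 values shown sit.

Compound 3 `O=C(N/N=C/c1ccccc1O)c1ccc(C(F)(F)F)cc1` has not yet been measured. It differs from compound 2 by having 2-hydroxyphenyl in place of 4-chlorophenyl on a carbon with a double bond to nitrogen.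

With compound 1 at > 100000 nM despite its hydroxyl, no clear change is expected here. The expected step, a number no higher from compound 2 to compound 3 (the limit leaves the size open), is no larger than the usual scatter, with neither direction favoured. For compound 3 the estimated value is 100000 nM, with an expected range from 40000 nM to 200000 nM.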

Compound 3, half-maximal inhibitory concentration: > 100000 nM
Compound 3: a limit, no number; the forecaster's own chance of this, stated with the estimate: 75%; the middle value sits exactly at the limit.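

Compound 3 also gives a limit and not a number, and no step can be read from compound 2 to compound 3 or from compound 1 to compound 3: the limit of > 100000 nM in this assay, at which 3 of the 3 values shown sit.

The compounds shown leave open whether any change to the shared core would give a readable number in this assay at all.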